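Compound 3 and its 3-(ethylamino)propoxy counterpart

A few compounds are considered here, and "the series" means these few. Any claim that something is new, unique, unknown or untested is made for them only; others in the source may bear on it.

In a functional assay on SK-BR-3 cells (Homo sapiens) for antiproliferative activity (on this read-out higher numbers stand for weaker inhibition and lower numbers for stronger inhibition), compound 1 (`CC(=O)Oc1ccc(C(=O)Nc2cc3ccc(OCC4CCCN(C)C4)c(C)c3oc2=O)cc1CC=C(C)C`) gives 740 nM, compound 2 (`CC(=O)Oc1ccc(C(=O)Nc2cc3ccc(OCC4CCCNC4)c(C)c3oc2=O)cc1CC=C(C)C`) gives 620 nM and compound 3 (`CC(C)=CCc1cc(C(=O)Nc2cc3ccc(OCC4CCCNC4)c(C)c3oc2=O)ccc1O`) gives 600 nM. All three numbers lie within the scatter of one another, so compound 3 stands level with the other two.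

Compound 4 (`CCNCCCOc1ccc2cc(NC(=O)c3ccc(O)c(CC=C(C)C)c3)c(=O)oc2c1C`) differs from compound 3 in its side chain: 2-(ethylamino)ethyl in place of piperidin-3-yl on a saturated chain carbon bound to an oxygen on an aromatic ring. Cut one bond further out, this is 3-(ethylamino)propoxy in place of (piperidin-3-yl)methoxy.

Two measured steps offer guidance. Hydrogen in place of methyl on the amine nitrogen in the ring gives a 1.2-fold lower number from compound 1 to compound 2 (0.08 log units; within the scatter), and hydrogen in place of acetyl on an oxygen on an aromatic ring gives a 1.0-fold lower number from compound 2 to compound 3 (0.01 log units; within the scatter). Both are within the scatter, but neither replaces the ring with an open chain, so they bear on this change only indirectly.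

The expected change is none beyond the scatter, with an estimated 1.1-fold higher number from compound 3 to compound 4 (0.03 log units; within the scatter).

For compound 4, the estimated value is 650 nM, with an expected range of 270 nM to 1600 nM.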

Compound 4, half-maximal inhibitory concentration: 720 nM
Beside the measured number, compound 4's estimate is 1.1-fold (0.04 log units) below it, and the stated range covers the measured number.
By their numbers in this assay, from the lowest: compounds 3, 2, 4 and 1 (each within the scatter of the next).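

In this assay the ring of the side chain proves dispensable at this position: with 2-(ethylamino)ethyl in place of piperidin-3-yl on a saturated chain carbon bound to an oxygen on an aromatic ring, the change is a 1.2-fold higher number from compound 3 to compound 4 (0.08 log units; within the scatter) and stays within the scatter. The earlier compounds shown here altered only what sat on the amine nitrogen in the ring or on the oxygen on the aromatic ring, and all of them kept the piperidin-3-yl group, so they could not show that an open chain holds level with it. No available evidence speaks to why the two side chains read alike.

The compounds shown leave open whether the amine in the side chain is needed at all, since every one of them carries an amine there. A hydroxyl or a carboxylic acid at the end of the chain, or a longer chain, remains an open case at this position.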